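A dimethylamino group added to compound 3

The source may hold more compounds than are shown below. What is called first, only, known or untested is meant among the compounds shown, and "the series" means these compounds.

Of the compounds shown here, three sharing one core have been measured in a physicochemical assay for solubility; a lower number here means a less soluble compound, a higher number a more soluble compound. Compound 1 `O=C(c1ccc(C(F)(F)F)cc1)N1CCC(NS(=O)(=O)c2cc(S(=O)(=O)c3ccccc3)ccc2C(F)(F)F)CC1`, with 4-(trifluoromethyl)phenyl on the carbonyl carbon, gives 6300 nM. Compound 2 `O=C(c1ccccn1)N1CCC(NS(=O)(=O)c2cc(S(=O)(=O)c3ccccc3)ccc2C(F)(F)F)CC1`, with pyridin-2-yl there, gives 100000 nM. Compound 3 `O=C(c1cccnc1)N1CCC(NS(=O)(=O)c2cc(S(=O)(=O)c3ccccc3)ccc2C(F)(F)F)CC1`, with pyridin-3-yl, gives 50000 nM.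

Compound 3 belongs with the high numbers of this small set. The swap between the two pyridines gives a 2.0-fold lower number from compound 2 to compound 3 (0.30 log units; within the scatter), so those two cannot be ranked. Replacing the 4-(trifluoromethyl)phenyl gives a 7.9-fold higher number from compound 1 to compound 3 (0.90 log units; beyond the scatter), and with the other pyridine a 16-fold higher number from compound 1 to compound 2 (1.20 log units; beyond the scatter).

Compound 4 `CN(C)c1ccc(C(=O)N2CCC(NS(=O)(=O)c3cc(S(=O)(=O)c4ccccc4)ccc3C(F)(F)F)CC2)cn1` differs from compound 3 in one place: dimethylamino in place of hydrogen on an aromatic carbon. The new dimethylamino group stands on an aromatic carbon, next to the ring nitrogen and para to a large group.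

For the measured compounds named here, no measured step makes this exact change, so the evidence is indirect. Among the measured compounds, only compound 1 carries a group other than hydrogen on the ring at the carbonyl, and its ring is not a pyridine. The step of a 7.9-fold higher number from compound 1 to compound 3 (0.90 log units; beyond the scatter) is therefore a loose guide, and it suggests a smaller fall here. The estimate is a step of a 2.5-fold lower number from compound 3 to compound 4 (0.40 log units; beyond the scatter), which is expected but uncertain. Compound 4 is expected to give about 20000 nM, within an estimated range of 5000 nM to 60000 nM.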

Compound 4, solubility: 12500 nM
Beside the measured number, compound 4's estimate is 1.6-fold (0.20 log units) above it; measured number inside the range.
By their numbers in this assay, from the lowest: compounds 1 and 4 (each within the scatter of the next); then compounds 3 and 2 (each within the scatter of the next).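

In this assay, dimethylamino in place of hydrogen on this aromatic carbon, next to the ring nitrogen, gives a 4.0-fold lower number from compound 3 to compound 4 (0.60 log units; beyond the scatter) and is the only step shown in which a pyridine ring on the carbonyl gains a group, so this position does not tolerate every change without a shift in the number. The change also sets compound 4 clearly apart from the pyridin-2-yl compound, with an 8.0-fold lower number from compound 2 to compound 4 (0.90 log units; beyond the scatter) in the same assay, while a 2.0-fold higher number from compound 1 to compound 4 (0.30 log units; within the scatter) leaves compound 4 and the 4-(trifluoromethyl)phenyl compound unranked, a pair that the unsubstituted pyridines had kept well apart. Nothing available on these compounds accounts for the size of this step.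

A single group on a single carbon cannot show whether a smaller amine such as methylamino, a ring amine such as morpholine, or a carboxylic acid at the same place would lower the number as much, or lower it at all. On these data alone, it also remains open whether dimethylamino would give a step of similar size on the pyridin-2-yl ring of compound 2.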